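The compounds below may be only part of what the source reports. "The series", "measured", "known", "first", "only" and "open" are said of these compounds alone.

Working notes on the series, all compounds sharing the core of compound 1 `CNc1c(C(=O)NCc2ccc(F)cc2)nc(Br)c2cccnc12`. In a functional assay on MDA-MB-435 cells (Homo sapiens) for cytotoxicity, read by MTT assay, with a stated time of 72 h (a higher number here means a weaker inhibitor, a lower number a stronger inhibitor), compound 1 gives > 20000 nM, which is a limit of the assay. Compound 2 `Cc1ccc(S(=O)(=O)Oc2c(C(=O)NCc3ccc(F)cc3)nc(Br)c3cccnc23)cc1` gives > 20000 nM, also a limit. Going by the values given here, compound 3 `COC(=O)CNc1c(C(=O)NCc2ccc(F)cc2)nc(Br)c2cccnc12` gives 10000 nM, the only actual number so far. The other two values sit together: the limit of > 20000 nM in this assay, at which 2 of the 3 values shown sit.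

The next compound is compound 4 `NCCCCCCNc1c(C(=O)NCc2ccc(F)cc2)nc(Br)c2cccnc12`, which differs from compound 3 as follows: 5-aminopentyl in place of methoxycarbonyl on a saturated chain carbon bound to a nitrogen on an aromatic ring. In words, 5-aminopentyl takes the place of methoxycarbonyl on a saturated chain carbon bound to a nitrogen on an aromatic ring.

The closest measured change is an at least 2.0-fold lower number from compound 1 to compound 3 (0.30 log units; that floor lies within the scatter), which concerns the same place. The other step into the number is an at least 2.0-fold lower number from compound 2 to compound 3 (0.30 log units; that floor lies within the scatter). Both are floors only, and a step that the two limits leave unreadable from compound 1 to compound 2 offers nothing further. Among the compounds with values here, no measured compound carries the 5-aminopentyl group, so the size of this change has no direct precedent.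

With compound 3 at 10000 nM as the only anchor, no step beyond the scatter is expected in this assay. The expected change is a 1.7-fold lower number from compound 3 to compound 4 (0.22 log units; within the scatter). For compound 4 the estimated value is 6000 nM, with an expected range of 1500 nM to 20000 nM.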

Compound 4, half-maximal inhibitory concentration: 6000 nM
For compound 4 middle estimate and measured number coincide at the digits printed; the range from low to high includes it.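

In this assay, the place on a saturated chain carbon bound to a nitrogen on an aromatic ring accepts two very different groups, methoxycarbonyl and 5-aminopentyl, without a step beyond the scatter: a 1.7-fold lower number from compound 3 to compound 4 (0.22 log units; within the scatter). The series now has its first readable steps beyond the scatter, although both are floors: 5-aminopentyl in place of hydrogen at this position gives an at least 3.3-fold lower number from compound 1 to compound 4 (0.52 log units; beyond the scatter), and (6-aminohexyl)amino in place of ((4-methylphenyl)sulfonyl)oxy on an aromatic carbon gives an at least 3.3-fold lower number from compound 2 to compound 4 (0.52 log units; beyond the scatter). Compound 1 and compound 2 remain limits, not numbers, so these two steps have no upper size: the limit of > 20000 nM in this assay, at which 2 of the 4 values shown sit.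

The compounds shown leave open whether the terminal amine or the chain itself accounts for the floors, a question that a plain hexyl chain without the amine would help to separate. Also open, from the compounds shown here alone, is how a carboxylic acid in place of the methyl ester, or a longer aminoalkyl chain, would read in this assay.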